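Working notes on a small acid series, whole-animal dose

This account rests on a few compounds, and the source may have more. Where it says the series, first, only, none or still open, it means among the compounds named here.

Measured so far:
compound 1 `O=C(O)c1cnc2ccc(C3CCCCC3)cc2c1`: > 25 mg/kg
compound 2 `O=C(O)c1cnc2cc(C(F)(F)F)ccc2c1`: > 25 mg/kg

In a functional assay on the whole organism (strain Sprague-Dawley) for inhibition, with Rattus norvegicus as the target (on this read-out higher numbers stand for an effect only at larger amounts of compound and lower numbers for an effect already at smaller amounts), compound 1 gives > 25 mg/kg, which is a limit of the assay and not a number. Compound 2 in this assay gives > 25 mg/kg, again only a limit. Going by the values given here, both values sit at the limit of > 25 mg/kg in this assay, at which 2 of the 2 values shown sit, so no step between measured compounds can be drawn. Compound 3 `O=C(O)c1cnc2ccc(C(F)(F)F)cc2c1` differs from compound 1 by trifluoromethyl in place of cyclohexyl on an aromatic carbon. The expected step in this assay, a step that the limit leaves unreadable from compound 1 to compound 3, is none beyond the usual scatter. Compound 3 is expected to give 40 mg/kg in this assay, with a range from 15 mg/kg to 120 mg/kg.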

Compound 3, minimum effective dose: > 25 mg/kg
Compound 3 ended at the assay's limit; the forecaster's own chance of this, stated with the estimate: 75%; the middle value is on the limit's open side.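

No step can be read from compound 1 to compound 3, as both stand at a limit of the assay: the limit of > 25 mg/kg in this assay, at which 3 of the 3 values shown sit.

The compounds shown leave open what dose of any of these acids gives an effect, and whether trifluoromethyl and cyclohexyl differ at all.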